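A few compounds are considered here, and "the series" means these few. Any claim that something is new, unique, unknown or untested is made for them only; others in the source may bear on it.

Working notes on the series. In a functional assay on MCF7 cells (Homo sapiens) for inhibition, read by sulforhodamine B assay (on this read-out higher numbers stand for weaker inhibition and lower numbers for stronger inhibition), compound 1 `Cc1ccc(NC2=CC(=O)c3c(nc4n3[C@H]3OC[C@@H](O)[C@H]3OC4)C2=O)cc1C` gives 4950 nM. Compound 3 `O=C1C(NC2CC2)=CC(=O)c2c1nc1n2[C@H]2OC[C@@H](O)[C@H]2OC1`, which carries cyclopropyl in place of 3,4-dimethylphenyl on the amine nitrogen, gives > 16000 nM in this assay; that value is a limit of the assay, not a number. For the measured compounds named here, the step of an at least 3.2-fold higher number from compound 1 to compound 3 (0.50 log units; beyond the scatter) is the only measured step in the set. Compound 2 `O=C1C=C(NC2CCCC2)C(=O)c2c1nc1n2[C@H]2OC[C@@H](O)[C@H]2OC1` gives > 16000 nM in this assay; this too is a limit of the assay, not a number. Compound 2 therefore stands at the limit of > 16000 nM in this assay, at which 2 of the 3 values shown sit, among the weakest values shown, with no number of its own.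

Compound 4 `O=C1C=C(N2CCCC2)C(=O)c2c1nc1n2[C@H]2OC[C@@H](O)[C@H]2OC1` is not yet measured. It differs from compound 2 as follows: pyrrolidin-1-yl in place of cyclopentylamino on a double-bonded ring carbon. Going by the values given here, no measured step concerns this kind of change; the one measured step, from compound 1 to compound 3, alters the group on the amine nitrogen rather than replacing the amine by a ring nitrogen, so it gives no direct guide. With compound 2 already at the limit, compound 4 is expected to stay near it, the step that the limit leaves unreadable from compound 2 to compound 4 being an expectation only. The estimate for compound 4 in this assay is 20000 nM, with a range of 8000 nM to 50000 nM, and a high chance that only a limit is reported.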

Compound 4, half-maximal inhibitory concentration: > 16000 nM
Compound 4 ended at the assay's limit; the forecaster's own chance of this, stated with the estimate: 70%; the middle value is on the limit's open side.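

No step can be read between compound 2 and compound 4 because both stand at a limit of the assay rather than at a number: the limit of > 16000 nM in this assay, at which 3 of the 4 values shown sit.

The compounds shown leave open whether pyrrolidin-1-yl and cyclopentylamino differ at all in this assay.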